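This account rests on a few compounds, and the source may have more. Where it says the series, first, only, none or still open, it means among the compounds named here.

Working notes on the series. Compound 1 `O=C(CN1CCC(Cc2ccccc2)CC1)Nc1ccc(C(=O)/C=C/c2cn(Cc3ccc(Br)cc3)nn2)cc1` and compound 3 `O=C(CN1CCN(c2ccccc2)CC1)Nc1ccc(C(=O)/C=C/c2cn(Cc3ccc(Br)cc3)nn2)cc1` both carry a 4-bromophenyl on a saturated chain carbon bound to an aromatic nitrogen; how their two cores differ is not broken down here. In a functional assay on MCF7 cells (Homo sapiens) for inhibition, read by MTT assay (a higher number here means a weaker inhibitor, a lower number a stronger inhibitor), compound 1 gives 54500 nM and compound 3 gives 49200 nM, two numbers within the scatter of each other. Compound 2 `CCCCCCCCCCn1cc(/C=C/C(=O)c2ccc(NC(=O)CN3CCN(c4ccccc4)CC3)cc2)nn1` carries the change (nonyl in place of 4-bromophenyl on a saturated chain carbon bound to an aromatic nitrogen). In this assay compound 2 reaches only a limit, > 100000 nM. The step is therefore an at least 2.0-fold higher number from compound 3 to compound 2 (0.30 log units; that floor lies within the scatter), read against (the limit of > 100000 nM in this assay, at which 1 of the 3 values shown sits). Compound 4 `CCCCCCCCCCn1cc(/C=C/C(=O)c2ccc(NC(=O)CN3CCC(Cc4ccccc4)CC3)cc2)nn1` carries the same change on the core of compound 1, (nonyl in place of 4-bromophenyl on a saturated chain carbon bound to an aromatic nitrogen). Compound 4 is expected to move by a 2.8-fold higher number from compound 1 to compound 4 (0.44 log units; beyond the scatter). Going by the values given here, that expectation rests on the single measured instance, an at least 2.0-fold higher number from compound 3 to compound 2 (0.30 log units; that floor lies within the scatter). The estimate for compound 4 is 150000 nM, with a strong chance that only a limit is reported.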

Compound 4, half-maximal inhibitory concentration: 55200 nM
For compound 4 the middle estimate is 2.7-fold (0.43 log units) above the measured one; measured number below the stated range.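

In this assay, the change from 4-bromophenyl to nonyl on the core of compound 1 gives a 1.0-fold higher number from compound 1 to compound 4 (0.01 log units; within the scatter). This neither shows that the change carries over from one core to the other in the same way nor shows that its outcome depends on the core: the same change on two cores in this assay, an at least 2.0-fold higher number (0.30 log units; that floor lies within the scatter) from compound 3 to compound 2 and a 1.0-fold higher number (0.01 log units; within the scatter) from compound 1 to compound 4; the limit leaves it open whether they differ For compound 2, > 100000 nM is a limit and not a number.

The compounds shown leave open how a shorter chain, or a chain ending in an amine or a carboxylic acid, would read in place of nonyl on either core. Also open, as far as these compounds go, is whether any such group at this place would give a step beyond the scatter on the core of compound 1.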